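The compounds below may be only part of what the source reports. "The series", "measured", "known", "first", "only" and "open" are said of these compounds alone.

Measured in an assay for inhibition of Fatty-acid amide hydrolase 1 (Rattus norvegicus); on this read-out lower numbers stand for stronger inhibition and higher numbers for weaker inhibition:
compound 1 `O=C(CCc1ccc(-c2ccccc2)cc1)c1ncc(-c2cccnc2)o1`: 1.1 nM
compound 2 `COC(=O)c1cnc(C(=O)CCc2ccc(-c3ccccc3)cc2)o1`: 1.5 nM

Compound 2 holds the higher of the two numbers, yet the step between them is a 1.4-fold higher number from compound 1 to compound 2 (0.13 log units; within the scatter), within the scatter, so the two stand level. Compound 3 `CN(C)C(=O)c1cnc(C(=O)CCc2ccc(-c3ccccc3)cc2)o1` differs from compound 2 by dimethylamino in place of methoxy on a carbonyl carbon. No measured step touches this carbonyl substituent directly; the only step shown, a 1.4-fold higher number from compound 1 to compound 2 (0.13 log units; within the scatter), tells that the group on the aromatic carbon can be exchanged without a change beyond the scatter. A small step is therefore expected from compound 2 to compound 3, estimated as a 2.0-fold higher number from compound 2 to compound 3 (0.30 log units; within the scatter), with the number of compound 3 expected near 3 nM, between 1 nM and 10 nM.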

Compound 3, inhibition constant: 3 nM
Compound 3: the middle estimate sits on the measured number at the digits printed; the measured number falls inside the stated range.
By their numbers in this assay, from the lowest: compounds 1, 2 and 3 (each within the scatter of the next, the first and the last beyond it).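

In this assay the carbonyl carbon accepts dimethylamino in place of methoxy with a 2.0-fold higher number from compound 2 to compound 3 (0.30 log units; within the scatter), so this exchange stays within the scatter. Among these compounds, measured against pyridin-3-yl on the aromatic carbon, dimethylcarbamoyl gives a 2.7-fold higher number from compound 1 to compound 3 (0.44 log units; beyond the scatter), a modest change and the first step to pass beyond the scatter. Nothing available explains either step.

Still open, on these data alone, is how a carboxylic acid, a primary amide or a morpholine amide at this carbonyl carbon would compare with methoxy and dimethylamino. Also open, as far as these compounds go, is whether a longer ester keeps the number of compound 2 .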